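The source may hold more compounds than are shown below. What is called first, only, known or untested is meant among the compounds shown, and "the series" means these compounds.

In a functional assay on Coronary artery (Bos taurus) (on this read-out higher numbers stand for an effect only at larger amounts of compound and lower numbers for an effect already at smaller amounts), compound 1 `CCCCCNC(=O)NCCCC/C=C\CCCCCNS(=O)(=O)c1ccccc1` gives 3400 nM, compound 2 `CCCCCNC(=O)NCCCC/C=C\CCCCCS(=O)(=O)c1ncn[nH]1` gives 3100 nM and compound 3 `CCCCNC(=O)C(=O)NCCCC/C=C\CCCCCCc1nnn[nH]1` gives 1700 nM, so compound 1 stands within the usual scatter of both others. Compound 4 `CCCCCNC(=O)NCCCC/C=C\CCCCCCc1noc(=S)[nH]1` differs from compound 1 in one place: a group of 7 heavy atoms (3 carbon, 2 nitrogen, 1 oxygen, 1 sulfur; one five-membered aromatic ring with 3 hetero atoms) in place of a group of 10 heavy atoms (6 carbon, 1 nitrogen, 2 oxygen, 1 sulfur; one six-membered aromatic ring of carbon only), on a saturated chain carbon, five bonds along the chain from a double-bonded chain carbon. Among the measured compounds shown here, the one measured step that bears on this is a similar exchange for a five-membered aromatic ring with 3 hetero atoms, a 1.1-fold lower number from compound 1 to compound 2 (0.04 log units; within the scatter), which stayed within the scatter. For the measured compounds named here, compound 3 differs from compound 1 in more than one place and offers no clean step. In this assay, no change beyond the scatter is therefore expected, and the estimated step is a 1.5-fold lower number from compound 1 to compound 4 (0.19 log units; within the scatter). The estimate for compound 4 is 2200 nM, with an expected range from 700 nM to 7000 nM.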

Compound 4, half-maximal effective concentration: 3300 nM
Compound 4: the middle estimate sits 1.5-fold (0.18 log units) below what was measured; low and high end bracket the measured number.
By their numbers in this assay, from the lowest: compounds 3, 2, 4 and 1 (each within the scatter of the next).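

In this assay the exchange of the (phenylsulfonyl)amino group for a five-membered aromatic ring with 3 hetero atoms, directly on the same saturated chain carbon, gives a 1.0-fold lower number from compound 1 to compound 4 (0.01 log units; within the scatter) and so stays within the scatter. Swapping one such ring group for the other gives a 1.1-fold higher number from compound 2 to compound 4 (0.03 log units; within the scatter) and also stays within the scatter, so this position has yet to show a change beyond it. Nothing available explains this result. As far as these compounds go, whether a carboxylic acid or an amine at this place would move the number beyond the scatter remains open, as does the effect of a longer chain carrying the ring.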